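The source may report more compounds than this note shows. Statements on the series, on what has been measured and on what is new or still open speak of the compounds shown alone.

Among the measured compounds shown here, compound 1 `Nc1cc(Cc2ccn(Cc3cccc(-c4ccccc4)c3)n2)c2nn[nH]c2n1` stands with the highest number among the three compounds measured so far. In an assay on isolated protein for inhibition of Myeloperoxidase (Homo sapiens), with a stated time of 10 min (on this read-out lower numbers stand for stronger inhibition and higher numbers for weaker inhibition), compound 1 gives 55 nM. Compound 2 `Nc1cc(C2CCNCC3(CCCC3)COc3cccc(c3)Cn3cc2cn3)c2nn[nH]c2n1` gives 26 nM in this assay, and compound 3 `Nc1cc(C2CCNC3CCC(CC3)COc3cccc(c3)Cn3cc2cn3)c2nn[nH]c2n1` gives 31 nM. The gap between compound 1 and compound 3 lies within the usual scatter of such measurements, while the gap to compound 2 lies slightly beyond it. Compound 4 `Nc1cc(Cc2ccn(Cc3cccc(Oc4cccc5c4CNC5)c3)n2)c2nn[nH]c2n1` has not been measured yet. Compared with compound 1, it carries a group of 10 heavy atoms (8 carbon, 1 nitrogen, 1 oxygen; one five-membered non-aromatic ring with 1 hetero atom, one six-membered aromatic ring of carbon only) in place of a group of 6 heavy atoms (6 carbon; one six-membered aromatic ring of carbon only), on an aromatic carbon. For the measured compounds named here, no pair of measured compounds shows the effect of this kind of change, so the expectation rests on compound 1 alone. The step expected is a 1.1-fold lower number from compound 1 to compound 4 (0.04 log units; within the scatter), no larger than the scatter in either direction. Compound 4 is therefore estimated at 50 nM in this assay, with a range from 15 nM to 160 nM.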

Compound 4, half-maximal inhibitory concentration: 26 nM
Estimate against measurement, compound 4: 1.9-fold (0.28 log units) above; the range from low to high includes it.
By their numbers in this assay, from the lowest: compounds 2, 4, 3 and 1 (each within the scatter of the next, the first and the last beyond it).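

In this assay, putting the group of 10 heavy atoms in place of phenyl, on an aromatic carbon meta to a large group, gives a 2.1-fold lower number from compound 1 to compound 4 (0.33 log units; beyond the scatter). This position therefore tolerates a much larger group containing nitrogen and oxygen, with no loss of inhibition and a modest gain. No available evidence bears on what lies behind this step. The compounds shown do not separate the contributions of the nitrogen, the oxygen and the added size, nor show how a plain aminomethyl group or a carboxylic acid would fare here.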